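Swapping the Phenethyl Arm for a Thiophene Ring

The source may hold more compounds than are shown below. What is called first, only, known or untested is meant among the compounds shown, and "the series" means these compounds.

The measured compounds and their numbers:
compound 1, `C=C(Br)C(=O)Nc1cccc(-c2cn3nc(-c4ccc(OC)c(OC)c4)sc3n2)c1`, gives 380 nM in a functional assay on CCRF-CEM cells (Homo sapiens) for inhibition, read by cell counting, with a stated time of 3 days; a lower number here means a stronger inhibitor, a higher number a weaker inhibitor.
compound 2, `Nc1cccc(-c2cn3c(-c4ccc(Cl)cc4)csc3n2)c1`, gives 21000 nM in this assay.
compound 3, `C=C(Br)C(=O)Nc1cccc(-c2cn3nc(CCc4ccccc4)sc3n2)c1`, gives 4200 nM in this assay.

Compound 3 holds the second highest of the three numbers. Its nearest neighbour is compound 2, whose value is higher; its furthest is compound 1, whose value is lower, and both gaps lie beyond the scatter. Compound 2 has a different core and a free amine in place of the acrylamide, so its number only shows where it lies and supports no single-place comparison.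

For the measured compounds named here, the one step that can be read directly is an 11-fold higher number from compound 1 to compound 3 (1.04 log units; beyond the scatter): replacing an aromatic ring bound straight to the core with a two-carbon chain ending in a phenyl ring cost a large amount of inhibition.

Compound 4, `C=C(Br)C(=O)Nc1cccc(-c2cn3nc(-c4cccs4)sc3n2)c1`, returns toward that arrangement. The change is thiophen-2-yl in place of phenethyl on an aromatic carbon. An aromatic ring again sits directly on the aromatic carbon of the fused core, though a smaller five-membered one bearing sulfur rather than the 3,4-dimethoxyphenyl of compound 1. Because the step of an 11-fold higher number from compound 1 to compound 3 (1.04 log units; beyond the scatter) was large, a step of similar size in the opposite direction is expected, though whether the thiophene recovers the full amount is uncertain. For compound 4 the expected step is a 4.7-fold lower number from compound 3 to compound 4 (0.67 log units; beyond the scatter), and its estimated value is 900 nM, with a range from 250 nM to 3200 nM.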

Compound 4, half-maximal inhibitory concentration: 410 nM
Estimate against measurement, compound 4: 2.2-fold (0.34 log units) above; the range from low to high includes it.
By their numbers in this assay, from the lowest: compounds 1 and 4 (each within the scatter of the next); then compound 3; then compound 2.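

In this assay the change to thiophen-2-yl gives a 10-fold lower number from compound 3 to compound 4 (1.01 log units; beyond the scatter), which shows that the loss seen with the phenethyl arm on this aromatic carbon can be reversed by a ring other than 3,4-dimethoxyphenyl. The further step, a 1.1-fold higher number from compound 1 to compound 4 (0.03 log units; within the scatter), lies within the scatter, so a five-membered aromatic ring with one sulfur and a six-membered ring carrying two methoxy groups cannot be told apart here, and those methoxy groups are not required for a number of this size. Among the compounds on this shared core, the two with an aromatic ring bound directly to this carbon lie within the scatter of each other and compound 3 alone stands apart, but no measurement shown explains this difference.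

Going by these compounds, what remains open is whether the length of the chain or the loss of the direct aromatic attachment accounts for the phenethyl result, which benzyl, plain phenyl or a saturated cyclohexyl ring at this position could help separate. Steps to compound 2 cannot be read, and the compounds shown also leave untested how furan-2-yl, pyridin-3-yl or a thiophene bearing a chlorine would compare with thiophen-2-yl.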